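Pyridine halogen to methyl and dog clearance

The source may hold more compounds than are shown below. What is called first, only, known or untested is meant among the compounds shown, and "the series" means these compounds.

Compound 2 `C[C@@H](NC(=O)C1(NC(=O)c2cncc(Br)c2)CC1)c1ccc(-n2nc(Cl)c3ccccc32)cc1F` stands highest of the two numbers in an in vivo ADME assay on the whole organism (strain Mongrel) for pharmacokinetics, with Canis familiaris (Canis lupus familiaris) as the target (on this read-out higher numbers stand for fast clearance and lower numbers for slow clearance), where compound 2 gives 3.8 mL/min/kg; its nearest neighbour is compound 1 `C[C@@H](NC(=O)C1(NC(=O)c2cncc(Cl)c2)CC1)c1ccc(-n2nc(Cl)c3ccccc32)cc1F`, which gives 3.1 mL/min/kg. For the measured compounds named here, the only measured step, a 1.2-fold higher number from compound 1 to compound 2 (0.09 log units; within the scatter), lies within the scatter. Compound 3 `Cc1cncc(C(=O)NC2(C(=O)N[C@H](C)c3ccc(-n4nc(Cl)c5ccccc54)cc3F)CC2)c1` carries methyl in place of bromo on an aromatic carbon. Going by the values given here, no measured step swaps bromo for methyl, so the bromo-for-chloro step is the sole guide; it was small, and a step of similar size, a 1.1-fold lower number from compound 2 to compound 3 (0.04 log units; within the scatter), is expected here, with no direction beyond the scatter. For compound 3 the estimate is 3.5 mL/min/kg, within 1.8 mL/min/kg to 7 mL/min/kg.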

Compound 3, clearance: 4.3 mL/min/kg
Beside the measured number, compound 3's estimate is 1.2-fold (0.09 log units) below it, and the stated range covers the measured number.
By their numbers in this assay, from the lowest: compounds 1, 2 and 3 (each within the scatter of the next).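

In this assay, the change from bromo to methyl gives a 1.1-fold higher number from compound 2 to compound 3 (0.05 log units; within the scatter) and the change from chloro to methyl gives a 1.4-fold higher number from compound 1 to compound 3 (0.14 log units; within the scatter). A non-halogen group on this pyridine carbon therefore cannot be told apart from either halogen on this read-out, so the flat picture now extends beyond the chloro and bromo pair. No supporting data bear on this result.

Still open, going by these compounds, is whether an amine, a carboxylic acid or a methoxy group on the same carbon would move clearance beyond the scatter. On these data alone, whether methyl behaves the same way on a different core also remains open.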